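Swapping (Oxolan-2-yl)methyl for sec-Butyl on the Core

The source may hold more compounds than are shown below. What is called first, only, known or untested is meant among the compounds shown, and "the series" means these compounds.

Of the compounds shown here, three built on one shared core have been measured. Compound 1 `CCCCn1cc(C(=O)C(=O)Nc2ccc(OC)nc2)c2ccccc21` gives 18 nM in a functional assay on FaDu cells (Homo sapiens) for cytotoxicity, read by MTT assay, with a stated time of 72 h; on this read-out lower numbers stand for higher toxicity in this test and higher numbers for lower toxicity in this test. Compound 2 `COC(=O)CCn1cc(C(=O)C(=O)Nc2ccc(OC)nc2)c2ccccc21` gives 168 nM in this assay, and compound 3 `COc1ccc(NC(=O)C(=O)c2cn(CC3CCCO3)c3ccccc23)cn1` gives 31 nM in this assay. Among these three numbers compound 3 holds the second highest: it sits within the scatter of compound 1, as a 1.7-fold higher number from compound 1 to compound 3 (0.24 log units; within the scatter) shows, and clearly apart from compound 2, with a 5.4-fold lower number from compound 2 to compound 3 (0.73 log units; beyond the scatter). Compound 4 `CCC(C)n1cc(C(=O)C(=O)Nc2ccc(OC)nc2)c2ccccc21` is not yet measured. It differs from compound 3 in one place: sec-butyl in place of (oxolan-2-yl)methyl on an aromatic nitrogen. Going by the values given here, two measured steps concern the same chain on the aromatic nitrogen. Putting oxolan-2-yl in place of propyl mattered little, a 1.7-fold higher number from compound 1 to compound 3 (0.24 log units; within the scatter), whereas putting oxolan-2-yl in place of (methoxycarbonyl)methyl was a modest step, a 5.4-fold lower number from compound 2 to compound 3 (0.73 log units; beyond the scatter). A plain sec-butyl chain resembles the chain of compound 1 more than that of compound 2, so no step beyond the scatter is expected in this assay. Compound 4 is therefore estimated at 30 nM, with a range from 12 nM to 80 nM, which means an expected step of a 1.0-fold lower number from compound 3 to compound 4 (0.01 log units; within the scatter).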

Compound 4, concentration lethal to 50% of the cells: 68 nM
The estimate for compound 4 lay 2.3-fold (0.36 log units) below the measured number, and the stated range covers the measured number.
By their numbers in this assay, from the lowest: compounds 1 and 3 (each within the scatter of the next); then compound 4; then compound 2.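

Chain shape on the aromatic nitrogen matters in this assay, not just which atoms the chain contains: sec-butyl in place of butyl is a modest change (a 3.8-fold higher number from compound 1 to compound 4 (0.58 log units; beyond the scatter)), so these two all-carbon chains do not read alike. The (oxolan-2-yl)methyl chain, which stands within the scatter of butyl, also stands apart from sec-butyl (a 2.2-fold higher number from compound 3 to compound 4 (0.34 log units; beyond the scatter)), while sec-butyl still gives a lower number than 2-(methoxycarbonyl)ethyl (a 2.5-fold lower number from compound 2 to compound 4 (0.39 log units; beyond the scatter)), placing compound 4 in the middle of the series. Nothing available explains these differences.

As far as these compounds go, whether the rise comes from the branch itself remains open, and a smaller branched group such as isopropyl or a larger one such as tert-butyl could help to test this. From the compounds shown here alone, how a chain ending in an amine or a carboxylic acid would read at this position also remains open.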